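Replacing iodo with nitro in a cytotoxic series

The source may hold more compounds than are shown below. What is called first, only, known or untested is meant among the compounds shown, and "the series" means these compounds.

Measured in a functional assay on MCF7 cells (Homo sapiens) for cytotoxicity, read by MTT assay, with a stated time of 48 h; on this read-out higher numbers stand for weaker inhibition and lower numbers for stronger inhibition:
compound 1 `C/C(=N\NC(=S)Nc1ccc(I)cc1)c1ccccn1`: 6.61 nM
compound 2 `CC(=NNC(=S)Nc1cccc(F)c1)c1ccccn1`: 9 nM
compound 3 `C/C(=N/NC(=S)Nc1ccc(F)cc1)c1ccccn1`: 1.2 nM

Working notes. In this assay compound 1 stands at 6.61 nM (the number of compound 2 lies within the scatter of it). Compound 3 at 1.2 nM has a lower number than compound 1, and that gap lies beyond the scatter. With only these three values, no trend across the series can be claimed.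

The open question is compound 4 `C/C(=N\NC(=S)Nc1ccc([N+](=O)[O-])cc1)c1ccccn1`, which has not yet been measured. It carries nitro in place of iodo on an aromatic carbon, para to a large group (the count: nitro in place of iodo on an aromatic carbon). For the measured compounds named here, no pair of measured compounds differs in one place only, leaving no measured step to carry over to this change. Going by the values given here, the only guide is the spread of the series, from compound 3 at 1.2 nM to compound 2 at 9 nM, and this calls for a wide range.

No step beyond the scatter is expected in this assay, and the estimated step of a 1.3-fold lower number from compound 1 to compound 4 (0.12 log units; within the scatter) carries only a weak lean toward a lower number. For compound 4 the estimated value is 5 nM, with the expected range running from 1.2 nM to 22 nM as a working figure.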

Compound 4, half-maximal inhibitory concentration: 52 nM
Beside the measured number, compound 4's estimate is 10-fold (1.02 log units) below it; the whole stated range lies below it.
By their numbers in this assay, from the lowest: compound 3; then compounds 1 and 2 (each within the scatter of the next); then compound 4.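

In this assay the series now has its first step with a single change, nitro in place of iodo on an aromatic carbon, para to a large group: the step is a 7.9-fold higher number from compound 1 to compound 4 (0.90 log units; beyond the scatter), which lies beyond the scatter and runs toward weaker inhibition. For the compounds shown here, this shows that the position is not indifferent to the group it carries, at least on the core of compound 1, something the earlier compounds could not show with no single-change pair among them. Nothing measured alongside the step accounts for its direction or size, so the data give no explanation for it.

As far as these compounds go, the step rests on one pair, so it remains open whether the higher number is particular to nitro or would also appear with other replacements for iodo at this position, such as an amine, a carboxylic acid or a methoxy group. From the compounds shown here alone, it also remains open whether the same exchange would give a step of similar size on another compound of the series, as one pair cannot establish a trend.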